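The source may report more compounds than this note shows. Statements on the series, on what has been measured and on what is new or still open speak of the compounds shown alone.

Compound 3 `Cc1cc(C)cc(Cn2c(=O)cc(N3CCCCC3)n(Cc3ccccc3)c2=O)c1` carries a piperidin-1-yl on the shared core. In an ADME assay on MT4 cells (Homo sapiens) for cytotoxicity, read by MTT assay, with a stated time of 4 days (on this read-out lower numbers stand for higher toxicity in this test and higher numbers for lower toxicity in this test), compound 3 gives 47000 nM. Compound 2 `Cc1cc(C)cc(Cn2c(=O)cc(N3CCCC3)n(Cc3ccccc3)c2=O)c1` gives 31000 nM in this assay, and the two values sit within the scatter of each other: a 1.5-fold higher number from compound 2 to compound 3 (0.18 log units; within the scatter). Compound 1 `Cc1cc(C)cc(Cn2c(=O)cc(NCc3ccccc3)n(Cc3ccccc3)c2=O)c1` reaches only the limit of this assay, > 100000 nM. Against that limit the steps of an at least 3.2-fold lower number from compound 1 to compound 2 (0.50 log units; beyond the scatter) and an at least 2.1-fold lower number from compound 1 to compound 3 (0.32 log units; beyond the scatter) are at least modest, as the limit of > 100000 nM in this assay, at which 1 of the 3 values shown sits, allows no more to be said. Compound 4 `Cc1cc(C)cc(Cn2c(=O)cc(N(C)C)n(Cc3ccccc3)c2=O)c1` differs from compound 3 by dimethylamino in place of piperidin-1-yl on an aromatic carbon. Among the compounds with values here, no measured step swaps a ring amine for dimethylamino. The two ring amines lie close together, so for compound 4 only a small step is expected, a 1.3-fold higher number from compound 3 to compound 4 (0.11 log units; within the scatter), toward a higher number if anything. For compound 4 the estimate is 60000 nM, in the range 25000 nM to 150000 nM.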

Compound 4, half-maximal cytotoxic concentration: 48000 nM
Compound 4: the middle estimate sits 1.3-fold (0.10 log units) above what was measured; the range from low to high includes it.
By their numbers in this assay, from the lowest: compounds 2, 3 and 4 (each within the scatter of the next). At a limit, above all of these: compound 1.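

Dimethylamino, with no ring, stands level with both ring amines in this assay: a 1.0-fold higher number from compound 3 to compound 4 (0.01 log units; within the scatter), and a 1.5-fold higher number from compound 2 to compound 4 (0.19 log units; within the scatter). Among compound 2, compound 3 and compound 4, a ring at this position therefore makes no readable difference. The step from benzylamino, an at least 2.0-fold lower number from compound 1 to compound 4 (0.31 log units; beyond the scatter), is bounded on one side only, as compound 1 stands at a limit: the limit of > 100000 nM in this assay, at which 1 of the 4 values shown sits.

Open, as far as these compounds go, is whether the gap to compound 1 follows the hydrogen on its nitrogen or its benzyl group; methylamino or a plain amino group would separate the two. From the compounds shown here alone, how morpholin-4-yl would sit against these values also remains open.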